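Extending the Ester Chain by One More Carbon

The source may report more compounds than this note shows. Statements on the series, on what has been measured and on what is new or still open speak of the compounds shown alone.

In a functional assay on A549 cells (Homo sapiens) for cytotoxicity, read by MTT assay, with a stated time of 24 h, tested at 60 uM (on this read-out higher numbers stand for a weaker effect at the one concentration tested and lower numbers for a stronger effect), compound 3 `CCCCCCCCCCOC(=O)CCC(=O)N1CCN(CCCOc2cc3c(Nc4ccc(F)c(Cl)c4)ncnc3cc2OC)CC1` gives 3.9%, the lowest of the three numbers recorded so far. Compound 1 `CCCOC(=O)CCC(=O)N1CCN(CCCOc2cc3c(Nc4ccc(F)c(Cl)c4)ncnc3cc2OC)CC1` gives 70.4%, and compound 2 `CCCCCCCOC(=O)CCC(=O)N1CCN(CCCOc2cc3c(Nc4ccc(F)c(Cl)c4)ncnc3cc2OC)CC1` gives 35.7%. Every step among these three was large and beyond the scatter: a number 34.7 percentage points lower from compound 1 to compound 2 (beyond the scatter), a number 31.8 percentage points lower from compound 2 to compound 3 (beyond the scatter), and across both, a number 66.5 percentage points lower from compound 1 to compound 3 (beyond the scatter). Compound 4 `CCCCCCCCCCCOC(=O)CCC(=O)N1CCN(CCCOc2cc3c(Nc4ccc(F)c(Cl)c4)ncnc3cc2OC)CC1` differs from compound 3 by methyl in place of hydrogen on a saturated chain carbon, ten or more bonds along the chain from an oxygen next to a carbonyl group. Each earlier change added a longer group to the same chain and lowered the read-out in this assay; the present change adds the smallest group yet, and compound 3 already stands close to the bottom of the scale because 3.9% leaves little room for a further fall. The account therefore expects a step of a number 0.9 percentage points lower from compound 3 to compound 4 (within the scatter), essentially within the scatter. For compound 4 in this assay the estimate is 3%, with a range from 0% to 12%.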

Compound 4, a percentage reported as activity, at one concentration (the size of the read-out at that concentration, not a potency): 3.9%
Compound 4: middle estimate off by 0.9 percentage points, on the low side; the range from low to high includes it.
By their numbers in this assay, from the lowest: compounds 3 and 4 (each within the scatter of the next); then compound 2; then compound 1.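

In this assay, among these compounds, the methyl at this far end of the ester chain gives no change at the digits printed from compound 3 to compound 4 (within the scatter), the first step that lies within the scatter, whereas each earlier lengthening of the chain gave a large step. Compound 4 keeps the full distance from the shorter esters, with a number 31.8 percentage points lower from compound 2 to compound 4 (beyond the scatter) and a number 66.5 percentage points lower from compound 1 to compound 4 (beyond the scatter), so the series shows that the read-out no longer separates the chains once they reach the length of compound 3 and compound 4. Nothing given here bears on why the read-out follows the chain in this way.

On these data alone, it remains open whether a longer chain, or a chain ending in an amine or a carboxylic acid, would stay at this level. A single concentration also leaves open whether compound 3 and compound 4 would separate at lower concentrations.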